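This account rests on a few compounds, and the source may have more. Where it says the series, first, only, none or still open, it means among the compounds named here.

Measured compounds in an ADME assay on Vero cells (Chlorocebus sabaeus) for cytotoxicity; on this read-out lower numbers stand for stronger inhibition and higher numbers for weaker inhibition: compound 1 `COC(=O)c1c(C)[n+]([O-])c2ccc(OC)cc2[n+]1[O-]`; compound 2 `CCc1c(C(=O)OC)[n+]([O-])c2cc(C)c(C)cc2[n+]1[O-]`; compound 3 `CCc1c(C(=O)OC)[n+]([O-])c2cc(C)ccc2[n+]1[O-]`.

In this assay compound 1 gives 52.6 ug/mL. For compound 2 only the limit > 62.5 ug/mL is reported. For compound 3 likewise only the limit > 62.5 ug/mL is reported, so compound 3 stands at a limit and not at a number; the limit of > 62.5 ug/mL in this assay, at which 2 of the 3 values shown sit, is where two of the three values sit. Going by the values given here, the single measured step, a step that the two limits leave unreadable from compound 2 to compound 3, has no readable size. Compound 4 `CCc1c(C(=O)OC)[n+]([O-])c2cc(OC)ccc2[n+]1[O-]` differs from compound 3 by methoxy in place of methyl on an aromatic carbon. Among the compounds with values here, no measured step covers this change; compound 1, which also carries a methoxy, gives a number just under the limit. Compound 4 is therefore expected close to that number, and the expected step of an at least 1.0-fold lower number from compound 3 to compound 4 (0.03 log units; that floor lies within the scatter) cannot be read against a limit. The estimate for compound 4 is 58 ug/mL, with a range of 35 ug/mL to 100 ug/mL.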

Compound 4, half-maximal inhibitory concentration: 40 ug/mL
Compound 4: middle estimate off by 1.5-fold (0.16 log units), on the high side; the measured number falls inside the stated range.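

Methoxy in place of methyl on this aromatic carbon, meta to a fused ring and para to a fused ring, gives in this assay an at least 1.5-fold lower number from compound 3 to compound 4 (0.19 log units; that floor lies within the scatter). This size is only a floor, because one end of the step is a limit and not a number: the limit of > 62.5 ug/mL in this assay, at which 2 of the 4 values shown sit.
Methyl in place of hydrogen on a saturated chain carbon bound to an aromatic carbon gives a 1.3-fold lower number from compound 1 to compound 4 (0.12 log units; within the scatter), so with methoxy in place this chain change shows no readable difference.

As far as these compounds go, whether the methoxy step truly exceeds the scatter stays open. Also open, from the compounds shown here alone, is whether an amine or a carboxylic acid on this aromatic carbon, or a longer chain, would shift the number beyond it.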